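The source may hold more compounds than are shown below. What is called first, only, known or untested is meant among the compounds shown, and "the series" means these compounds.

Working notes on the series. Three analogues sharing one core have been run in an in vitro functional assay on cells for agonist activity at Bombesin receptor subtype-3 (Homo sapiens), read by luminescence and calcium flux; on this read-out higher numbers stand for an effect only at larger amounts of compound and lower numbers for an effect already at smaller amounts. Compound 1 `CCCCc1cnc(CCc2ccc(-c3ccccc3C(=O)O)cc2)[nH]1` gives 2710 nM. Compound 2 `CC(C)(C)c1cnc(CCc2ccc(-c3ccccc3C(=O)O)cc2)[nH]1` gives 4330 nM. Compound 3 `O=C(O)c1ccccc1-c1ccc(CCc2ncc(CCc3ccccc3)[nH]2)cc1` gives 1320 nM, the lowest of the three numbers: the step of a 2.1-fold lower number from compound 1 to compound 3 (0.31 log units; beyond the scatter) and the step of a 3.3-fold lower number from compound 2 to compound 3 (0.52 log units; beyond the scatter) both lie beyond the scatter, while a 1.6-fold higher number from compound 1 to compound 2 (0.20 log units; within the scatter) does not.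

Compound 4 `O=C(O)c1ccccc1-c1ccc(CCc2ncc(Cc3ccccc3)[nH]2)cc1` has not yet been measured in this assay. It differs from compound 3 in one place: phenyl in place of benzyl on a saturated chain carbon bound to an aromatic carbon. Cut one bond further out, the same difference reads phenethyl to benzyl, so the six-membered aromatic ring of carbon only is kept and the saturated chain to it is shortened.

The measured steps bear on this only at a distance. The step of a 2.1-fold lower number from compound 1 to compound 3 (0.31 log units; beyond the scatter) shows that putting the aromatic ring at the end of the chain brings the number down modestly; the step of a 3.3-fold lower number from compound 2 to compound 3 (0.52 log units; beyond the scatter) shows the same ring at the end of a phenethyl doing better than a tert-butyl. Neither step alters the length of the chain that carries the ring, which is what changes here. Compound 4 is therefore expected to give a number close to that of compound 3, with a slight lean upward, a step of a 1.4-fold higher number from compound 3 to compound 4 (0.13 log units; within the scatter), and the estimate for compound 4 in this assay is 1800 nM with a range from 700 nM to 4500 nM.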

Compound 4, half-maximal effective concentration: 205 nM
Compound 4: middle estimate off by 8.8-fold (0.94 log units), on the high side; the measured number lies below the stated range.
By their numbers in this assay, from the lowest: compound 4; then compound 3; then compounds 1 and 2 (each within the scatter of the next).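

In this assay, among the compounds shown here, the length of the saturated chain carrying the aromatic ring matters at this position: shortening phenethyl to benzyl, with the ring itself kept, gives a 6.4-fold lower number from compound 3 to compound 4 (0.81 log units; beyond the scatter), an effect that no earlier pair could show, as none of them altered that chain while keeping the ring. Benzyl also stands well apart from the two purely saturated groups at the same place, with a 21-fold lower number from compound 2 to compound 4 (1.32 log units; beyond the scatter) against tert-butyl and a 13-fold lower number from compound 1 to compound 4 (1.12 log units; beyond the scatter) against butyl, both steps large and beyond the scatter, so the earlier gain seen with phenethyl understated what an aromatic ring can bring here. Nothing at hand accounts for the size of this change in chain length.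

The compounds shown leave open whether the number keeps falling with a still shorter link, as with a phenyl set directly on the aromatic carbon, or rises again with a longer chain such as phenylpropyl, so two chain lengths do not yet define an optimum. They also leave open whether the benzyl ring tolerates added groups such as fluoro or methoxy, or replacement by a pyridine ring.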